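The source may hold more compounds than are shown below. What is called first, only, known or untested is meant among the compounds shown, and "the series" means these compounds.

In an ADME assay (liver, Mus musculus) for metabolic stability, using microsomes (a higher number here means that the compound lasts longer, a lower number that the compound disappears faster), compound 1 `C=CC(=O)Nc1cccc(CNc2nc(Nc3cnn(C(F)F)c3)ncc2Cl)c1` gives 0.173 h as its half-life, and compound 2 `C=CC(=O)Nc1cccc(CNc2nc(Nc3cnn(CCN(C)C)c3)ncc2Cl)c1` gives 0.03 h as its half-life, the lower of the two numbers. Compound 3 `C=CC(=O)Nc1cccc(CNc2nc(Nc3cnn(CCOC)c3)ncc2Cl)c1` carries methoxy in place of dimethylamino on a saturated chain carbon, two bonds along the chain from an aromatic nitrogen. Among the compounds with values here, only one measured step bears on this change, a 5.8-fold lower number from compound 1 to compound 2 (0.76 log units; beyond the scatter) on going from difluoromethyl to 2-(dimethylamino)ethyl on an aromatic nitrogen, and it bears only loosely. Within the data shown here, that step replaced the whole group on the aromatic nitrogen, and no measured pair isolates the present change. A rise of smaller size than that step is therefore expected in this assay with a 2.3-fold higher number from compound 2 to compound 3 (0.37 log units; beyond the scatter) as the estimated change. Compound 3 is expected to show a half-life of 0.07 h (estimated range 0.03 h to 0.17 h).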

Compound 3, half-life: 0.055 h
Estimate against measurement, compound 3: 1.3-fold (0.10 log units) above; the range from low to high includes it.
By their numbers in this assay, from the lowest: compounds 2 and 3 (each within the scatter of the next); then compound 1.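

In this assay, methoxy in place of dimethylamino on a saturated chain carbon, two bonds along the chain from an aromatic nitrogen, gives a 1.8-fold higher number from compound 2 to compound 3 (0.26 log units; within the scatter), so this assay does not separate these two chain ends. 2-Methoxyethyl in place of difluoromethyl on the aromatic nitrogen gives a 3.1-fold lower number from compound 1 to compound 3 (0.50 log units; beyond the scatter), which shows that the shorter half-life relative to compound 1 is seen with either chain and does not require the dimethylamino group. Nothing available explains why these half-lives differ.

The compounds shown leave open whether the longer half-life of compound 1 belongs to difluoromethyl itself or to the absence of a 2-substituted ethyl chain. A plain ethyl or methyl group on the same aromatic nitrogen would separate these two readings, and a longer chain ending in methoxy would show whether chain length matters.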